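Dropping the fluoro from compound 3

The source may report more compounds than this note shows. Statements on the series, on what has been measured and on what is new or still open speak of the compounds shown alone.

Compound 3 `COc1cc(OC)cc(-c2ccc(-c3ccc(C(=N)N)c(F)c3)s2)c1` gives 123000 nM in an ADME assay on WI-38 cells (Homo sapiens) for cytotoxicity, read by MTT assay, with a stated time of 24 h; on this read-out lower numbers stand for stronger inhibition and higher numbers for weaker inhibition. That is the lowest of the three numbers recorded, yet it lies within the scatter of both compound 1 `COc1ccc(-c2ccc(-c3ccc(C(=N)N)cc3)s2)cc1`, which gives 192000 nM, and compound 2 `N=C(N)c1ccc(-c2ccc(-c3ccc(F)cc3)s2)cc1`, which gives 197000 nM. Compound 4 `COc1cc(OC)cc(-c2ccc(-c3ccc(C(=N)N)cc3)s2)c1` differs from compound 3 in one place: hydrogen in place of fluoro on an aromatic carbon. Among the measured compounds shown here, the only measured single step, a 1.0-fold higher number from compound 1 to compound 2 (0.01 log units; within the scatter), exchanges a different pair of groups and bears only loosely on this change. Given that step and the closeness of all three values, no step beyond the scatter is expected in this assay, in either direction. Compound 4 is estimated at 160000 nM, within 80000 nM to 320000 nM. The expected step is a 1.3-fold higher number from compound 3 to compound 4 (0.11 log units; within the scatter).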

Compound 4, half-maximal inhibitory concentration: 73900 nM
Beside the measured number, compound 4's estimate is 2.2-fold (0.34 log units) above it; measured number below the stated range.
By their numbers in this assay, from the lowest: compounds 4, 3, 1 and 2 (each within the scatter of the next, the first and the last beyond it).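

In this assay, among the compounds shown here, this is the first direct reading of the aromatic carbon ortho to a group of 3 heavy atoms and meta to a large group: hydrogen in place of fluoro gives a 1.7-fold lower number from compound 3 to compound 4 (0.22 log units; within the scatter). At this place, in this compound pair, the exchange therefore produces no step beyond the scatter. No evidence is available that bears on this result. The compounds shown leave open whether a chloro, methyl or hydroxyl group at this place would behave likewise. They also leave open whether fluoro and hydrogen read alike on the core of compound 1.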